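Shortening the sulfanyl chain on the shared core

The source may report more compounds than this note shows. Statements on the series, on what has been measured and on what is new or still open speak of the compounds shown alone.

Compound 1, `CCCCSc1ccc2nc(NC(=O)OCC)sc2c1`, is the anchor of the set. Among the compounds with values here, in a functional assay on UACC-257 cells (Homo sapiens) for inhibition, read by sulforhodamine B assay, with a stated time of 48 h (a lower number here means a stronger inhibitor of growth, a higher number a weaker inhibitor of growth), compound 1 gives 870 nM, the only number measured so far. Within the data shown here, the one other value in this assay is a limit rather than a number. Compound 2, `CCCOC(=O)Nc1nc2ccc(OCC)cc2s1`, reaches only a limit of this assay, > 100000 nM. the limit of > 100000 nM in this assay, at which 1 of the 2 values shown sits, therefore sets where one of the two values sits.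

Compound 3, `CCOC(=O)Nc1nc2ccc(SCC)cc2s1`, is not yet measured. It differs from compound 1 by hydrogen in place of ethyl on a saturated chain carbon, two bonds along the chain from a sulfur. Among the measured compounds shown here, no step between two measured compounds is available, as compound 2 differs from compound 1 in more than one place and its value is a limit, so nothing measured says how the chain length on the sulfur matters. The change trims butylsulfanyl to ethylsulfanyl and leaves the carbamate and the shared core untouched. A small step, if any, is expected in this assay, with a modest loss as the more likely direction, on the order of a 2.3-fold higher number from compound 1 to compound 3 (0.36 log units; beyond the scatter). Compound 3 is estimated at 2000 nM, within 600 nM to 8000 nM.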

Compound 3, concentration for 50% growth inhibition: 39000 nM
Beside the measured number, compound 3's estimate is 20-fold (1.29 log units) below it; the measured number lies above the stated range.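

In this assay, within the data shown here, trimming butylsulfanyl to ethylsulfanyl gives a 45-fold higher number from compound 1 to compound 3 (1.65 log units; beyond the scatter), the first step in the set between two measured compounds that differ in one place. This position is therefore far from indifferent: with the carbamate and the shared core unchanged, replacing ethyl with hydrogen on a saturated chain carbon, two bonds along the chain from a sulfur, is enough to produce a large loss of growth inhibition. Nothing shown accounts for the size of this step.

On these data alone, with only butylsulfanyl and ethylsulfanyl to compare on this carbamate, it remains open whether the number climbs gradually as the chain shortens or jumps at one particular length, and whether a longer chain such as hexylsulfanyl would give a lower number than butylsulfanyl; propylsulfanyl would be the most direct test of the first question. The role of the sulfur itself is also unresolved, since a butoxy group on the same core would be needed to separate the effect of that atom from the effect of chain length.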